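Cyclobutyl to Cyclohexyl in an Adenosine Receptor Series

The source may hold more compounds than are shown below. What is called first, only, known or untested is meant among the compounds shown, and "the series" means these compounds.

Three compounds share one core and differ only in the side arm. Compound 1 `CCCNC(=O)OC[C@H]1OC(n2cnc3c(NC4CCOC4)ncnc32)[C@H](O)[C@@H]1O` gives 235 nM in an assay on DDT1 cells (Cricetulus griseus) for binding affinity to adenosine receptor A1 (Homo sapiens), read by radioligand binding; on this read-out higher numbers stand for weaker inhibition and lower numbers for stronger inhibition. Compound 2 `CCCCNC(=O)OC[C@H]1OC(n2cnc3c(NC4CCOC4)ncnc32)[C@H](O)[C@@H]1O` gives 1410 nM in this assay, a step of a 6.0-fold higher number from compound 1 to compound 2 (0.78 log units; beyond the scatter). Compound 3 `O[C@@H]1[C@@H](CO/C(S)=N/C2CCC2)OC(n2cnc3c(NC4CCOC4)ncnc32)[C@@H]1O` gives 148 nM, the lowest of the three numbers: a 1.6-fold lower number from compound 1 to compound 3 (0.20 log units; within the scatter), while a 9.5-fold lower number from compound 2 to compound 3 (0.98 log units; beyond the scatter).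

Compound 4 `O[C@@H]1[C@@H](CO/C(S)=N/C2CCCCC2)OC(n2cnc3c(NC4CCOC4)ncnc32)[C@@H]1O` carries cyclohexyl in place of cyclobutyl on a double-bonded nitrogen. For the measured compounds named here, only one measured step adds carbon to a saturated part, a 6.0-fold higher number from compound 1 to compound 2 (0.78 log units; beyond the scatter), and it made the number higher. A larger ring is therefore expected to weaken binding modestly, not to strengthen it. Compound 4 is expected to give 550 nM, within 170 nM to 1800 nM. The expected step is a 3.7-fold higher number from compound 3 to compound 4 (0.57 log units; beyond the scatter), upward and likely beyond the scatter.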

Compound 4, inhibition constant: 253 nM
The estimate for compound 4 lay 2.2-fold (0.34 log units) above the measured number, and the stated range covers the measured number.
By their numbers in this assay, from the lowest: compounds 3, 1 and 4 (each within the scatter of the next); then compound 2.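

Going from cyclobutyl to cyclohexyl on a double-bonded nitrogen adds ring carbons, yet the number barely moves (in this assay: a 1.7-fold higher number from compound 3 to compound 4 (0.23 log units; within the scatter)), whereas the one earlier step that added carbon, on a saturated chain, went beyond the scatter. The cyclohexyl compound still sits clearly apart from the butyl chain compound (a 5.6-fold lower number from compound 2 to compound 4 (0.75 log units; beyond the scatter)) and level with the propyl chain compound (a 1.1-fold higher number from compound 1 to compound 4 (0.03 log units; within the scatter)). Nothing at hand explains this tolerance of ring size. On these data alone, whether a phenyl ring or a piperidine ring at this place would read the same remains open.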